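This account rests on a few compounds, and the source may have more. Where it says the series, first, only, none or still open, it means among the compounds named here.

Compound 3 `Cc1cccc(CN(C)C(=O)c2nn(-c3ccc(F)cc3)c(OC[C@@H](O)C[C@@H](O)CC(=O)O)c2C(C)C)c1` is one of three closely related compounds measured in an assay on microsomes from liver for inhibition of 3-hydroxy-3-methylglutaryl-coenzyme A reductase (Rattus norvegicus) (on this read-out lower numbers stand for stronger inhibition and higher numbers for weaker inhibition), where compound 3 gives 37 nM. Compound 1 `CC(C)c1c(C(=O)NCc2ccccn2)nn(-c2ccc(F)cc2)c1OC[C@@H](O)C[C@@H](O)CC(=O)O` gives 25 nM, and the two numbers lie within the usual scatter, as a 1.5-fold higher number from compound 1 to compound 3 (0.17 log units; within the scatter) shows. Compound 2 `CC(C)c1c(C(=O)NCc2ccccc2Cl)nn(-c2ccc(F)cc2)c1OC[C@@H](O)C[C@@H](O)CC(=O)O` gives 9.5 nM; the step of a 3.9-fold higher number from compound 2 to compound 3 (0.59 log units; beyond the scatter) lies beyond the scatter, as does a 2.6-fold lower number from compound 1 to compound 2 (0.42 log units; beyond the scatter). Compound 4 `COc1cccc(CN(C)C(=O)c2nn(-c3ccc(F)cc3)c(OC[C@@H](O)C[C@@H](O)CC(=O)O)c2C(C)C)c1` differs from compound 3 by methoxy in place of methyl on an aromatic carbon. Among the measured compounds shown here, none of the measured steps exchanges a single small group on that aromatic ring; all three replace the whole group on the carbonyl carbon. For the measured compounds named here, with no step bearing directly on this change, compound 4 is expected to show no step beyond the scatter, a 1.1-fold lower number from compound 3 to compound 4 (0.02 log units; within the scatter), and the estimate for compound 4 is 35 nM with a range from 15 nM to 80 nM.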

Compound 4, half-maximal inhibitory concentration: 21 nM
Compound 4: middle estimate off by 1.7-fold (0.22 log units), on the high side, within the range that was stated.
By their numbers in this assay, from the lowest: compound 2; then compounds 4, 1 and 3 (each within the scatter of the next).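

In this assay, methoxy in place of methyl on this aromatic carbon leaves the number within the scatter (a 1.8-fold lower number from compound 3 to compound 4 (0.25 log units; within the scatter)), so the two groups cannot be told apart here. With the methoxy in place, the whole group on the carbonyl carbon still matches the pyridinyl version (a 1.2-fold lower number from compound 1 to compound 4 (0.08 log units; within the scatter)) but not the chlorinated one (a 2.2-fold higher number from compound 2 to compound 4 (0.34 log units; beyond the scatter)). No measurement at hand explains these numbers. As far as these compounds go, whether an amine, a hydroxyl or a carboxylic acid on this carbon would shift the number remains open. So does whether methoxy would behave alike on another carbon of the ring.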